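Dichloro-urea step in the thienopyrimidine urea series

The source may hold more compounds than are shown below. What is called first, only, known or untested is meant among the compounds shown, and "the series" means these compounds.

Measured so far:
compound 1 `CN(C)CCNc1nc(-c2ccc(NC(=O)Nc3ccc(F)cc3)cc2)nc2ccsc12`: 350 nM
compound 2 `CN(C)CCNc1nc(-c2ccc(NC(=O)Nc3ccc(Cl)cc3)cc2)nc2ccsc12`: 95 nM

In a functional assay on HT-29 cells (Homo sapiens) for cytotoxicity, read by MTT assay, with a stated time of 72 h (on this read-out higher numbers stand for weaker inhibition and lower numbers for stronger inhibition), compound 1 gives 350 nM. Among the measured compounds shown here, compound 2 gives 95 nM in this assay, the lowest of the two numbers; its only neighbour is compound 1, from which it differs by chloro in place of fluoro on an aromatic carbon, with a 3.7-fold lower number from compound 1 to compound 2 (0.57 log units; beyond the scatter).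

Compound 3 `CN(C)CCNc1nc(-c2ccc(NC(=O)Nc3ccc(Cl)cc3Cl)cc2)nc2ccsc12` has not been measured. It differs from compound 2 by chloro in place of hydrogen on an aromatic carbon, that is 4-chlorophenyl to 2,4-dichlorophenyl on the urea terminus. For the measured compounds named here, the only measured step that bears on it is the halogen exchange from compound 1 to compound 2, which moved the number modestly downward; no step on a second chloro at this ring exists. A second halogen on the same ring is expected to give at most a small further step downward, or none beyond the scatter, so compound 3 is expected to show a 1.6-fold lower number from compound 2 to compound 3 (0.20 log units; within the scatter). The estimate for compound 3 in this assay is 60 nM, within 20 nM to 200 nM.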

Compound 3, half-maximal inhibitory concentration: 1320 nM
Compound 3: middle estimate off by 22-fold (1.34 log units), on the low side, and the stated range ends below it.
By their numbers in this assay, from the lowest: compound 2; then compound 1; then compound 3.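

In this assay, chloro in place of hydrogen on the aromatic carbon ortho to a large group, which turns 4-chlorophenyl into 2,4-dichlorophenyl, gives a 14-fold higher number from compound 2 to compound 3 (1.14 log units; beyond the scatter). The earlier pair showed only a modest step for exchanging one halogen for another at a single ring position, and in the downward direction; this second chloro runs the other way, by a large step, and also puts the dichloro compound on the weak side of the fluoro compound, with a 3.8-fold higher number from compound 1 to compound 3 (0.58 log units; beyond the scatter). So the trend seen from fluoro to chloro does not extend to a further chloro on this ring, and nothing available here accounts for the reversal.

Still open, on these data alone, is whether this carbon ortho to a large group tolerates anything beyond hydrogen: a fluoro, methyl or methoxy group there, with the chloro meta to it kept, would separate the effect of this position from that of chloro itself. Also open, as far as these compounds go, is whether the same large step appears when this ring carries the chloro ortho to a large group with no second halogen.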